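This account rests on a few compounds, and the source may have more. Where it says the series, first, only, none or still open, it means among the compounds named here.

Compound 1 `Nc1ccnc2cc(C#Cc3c(F)cccc3F)ccc12` and compound 3 `Nc1ncc(C#Cc2c(F)cccc2F)c2ccccc12` are built from the same atoms joined differently; how their two cores differ is not broken down here. In a functional assay on LS174T cells (Homo sapiens) for inhibition, with a stated time of 4 days, tested at 1 uM (a higher number here means a stronger effect of the compound at the concentration tested, a lower number a weaker effect), compound 1 gives 23.6%, compound 3 gives 86.2%, and compound 2 `Fc1cccc(F)c1C#Cc1cncc2ccccc12` gives 16.5%. Compound 2 arises from compound 3 by the change (hydrogen in place of amino on an aromatic carbon), and that change brought a number 69.7 percentage points lower from compound 3 to compound 2 (beyond the scatter). The same kind of change, (hydrogen in place of amino on an aromatic carbon), turns compound 1 into compound 4 `Fc1cccc(F)c1C#Cc1ccc2cccnc2c1`, though the place is not the same: in compound 1 the amino sits opposite the ring nitrogen rather than next to it and para to a large group. Because compound 1 already sits at 23.6%, a shift as large as that from compound 3 to compound 2 cannot appear; the step to compound 4 is expected to be about a number 15.6 percentage points lower from compound 1 to compound 4 (beyond the scatter). Compound 4 is therefore estimated at 8%, likely between -5% and 22%.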

Compound 4, a percentage reported as inhibition, at one concentration (the size of the read-out at that concentration, not a potency): 90.7%
The estimate for compound 4 lay 82.7 percentage points below the measured number; the whole stated range lies below it.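

Putting hydrogen in place of amino brought a number 67.1 percentage points higher from compound 1 to compound 4 (beyond the scatter), so in this assay this change does not carry from one core to the other, and its direction reverses: the same change on two cores in this assay, a number 69.7 percentage points lower (beyond the scatter) from compound 3 to compound 2 and a number 67.1 percentage points higher (beyond the scatter) from compound 1 to compound 4, 136.8 percentage points apart, beyond the scatter of two such steps

The amino group therefore cannot be judged helpful or harmful on its own in this series, since its contribution to the read-out depends on where it stands and on which core. These two pairs do not show why: the core and the place of the amino group differ together, so their separate contributions cannot be told apart.

The compounds shown leave open how a methylamino or hydroxyl group would behave opposite the ring nitrogen. They also leave open what the same change would do on a third core.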